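The compounds below may be only part of what the source reports. "The series", "measured", "known", "first", "only" and "open" are said of these compounds alone.

The series is built around one carboxylic acid-bearing core carrying a substituted benzyloxy arm, studied in an assay on isolated protein for inhibition of prostaglandin E2 receptor EP1 subtype (Homo sapiens); a lower number here means a stronger inhibitor, a higher number a weaker inhibitor. Compound 2 `O=C(O)c1cccc(C2=C(c3cc(Br)ccc3OCc3ccccc3)CCC2)c1` gives 12.6 nM. Compound 1 `O=C(O)c1cccc(C2=C(c3cc(Br)ccc3OCc3ccc(F)cc3)CCC2)c1`, which carries the change (fluoro in place of hydrogen on an aromatic carbon), gives 20 nM; the step of a 1.6-fold higher number from compound 2 to compound 1 (0.20 log units; within the scatter) shows that this added fluoro left the readout essentially unchanged. Compound 3 `CS(=O)(=O)c1ccc(OCc2ccc(F)cc2)c(C2=C(c3cccc(C(=O)O)c3)CCC2)c1` gives 79.4 nM, and the step of a 4.0-fold higher number from compound 1 to compound 3 (0.60 log units; beyond the scatter) shows a modest loss when methylsulfonyl replaces bromo. Compound 3 therefore has the highest number of the three; the difference between the core of compound 3 and that of compound 2 is not broken down here.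

Compound 4 `CS(=O)(=O)c1ccc(OCc2ccc(F)cc2F)c(C2=C(c3cccc(C(=O)O)c3)CCC2)c1` has not yet been measured. It differs from compound 3 by fluoro in place of hydrogen on an aromatic carbon. For the measured compounds named here, this is the same kind of change as the one from compound 2 to compound 1, but not the same: in compound 1 the fluoro sits para to a large group, whereas in compound 4 it sits ortho to a large group and meta to a fluoro group. Going by the values given here, since the earlier addition of a fluoro gave only the step of a 1.6-fold higher number from compound 2 to compound 1 (0.20 log units; within the scatter), which is within the scatter, compound 4 is expected to stay close to compound 3, with the step of a 1.1-fold higher number from compound 3 to compound 4 (0.05 log units; within the scatter) anticipated. Compound 4 is accordingly estimated at 90 nM, with a plausible range from 40 nM to 200 nM, because compound 3 gives 79.4 nM.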

Compound 4, half-maximal inhibitory concentration: 15.9 nM
Estimate against measurement, compound 4: 5.7-fold (0.75 log units) above; measured number below the stated range.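

In this assay the fluoro added to compound 3 did not leave the readout unchanged but gave a gain, a 5.0-fold lower number from compound 3 to compound 4 (0.70 log units; beyond the scatter), so in this series the same formal change does not carry over from one core to another with the same size: the same change on two cores in this assay, a 1.6-fold higher number (0.20 log units; within the scatter) from compound 2 to compound 1 and a 5.0-fold lower number (0.70 log units; beyond the scatter) from compound 3 to compound 4, 7.9-fold (0.90 log units) apart, beyond the scatter of two such steps. What this does not show is where the gap comes from, since the two steps differ in more than the core: one builds a 4-fluorobenzyl arm from a plain benzyl arm on a bromo compound, while the other builds a 2,4-difluorobenzyl arm from a 4-fluorobenzyl arm on a methylsulfonyl compound, so the site of the fluoro and the bromo or methylsulfonyl group vary together. Each step also rests on a single pair of compounds, which gives a contrast between two cases and no general rule for this change.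

The compounds shown leave open whether a bromo compound with the 2,4-difluorobenzyl arm would show the same gain, which would separate the site of the fluoro from the influence of the core. They also leave open how the 2,4-difluorobenzyl arm behaves with a nitrile or a methoxy group in place of methylsulfonyl.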